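Swapping the Acetoxy Group of Compound 3

The compounds below may be only part of what the source reports. "The series", "measured", "known", "first", "only" and "open" are said of these compounds alone.

Compound 1 (`NS(=O)(=O)c1ccc(SCCO)c(C(=O)O)c1`), value (10.5)
Compound 2 (`COC(=O)c1cc(S(N)(=O)=O)ccc1SCCCO`), value (9.3)
Compound 3 (`CC(=O)OCCS(=O)(=O)c1ccc(S(N)(=O)=O)s1`), value (8.65)

All three values come from a physicochemical assay for acid dissociation, and make up the whole of the measured set. Compound 3, at 8.65 in this series, holds the lowest of the three numbers. Compound 2 stands higher and compound 1 higher still, and both gaps lie beyond the usual scatter.

Compound 4 (`COCC(=O)OCCCS(=O)(=O)c1ccc(S(N)(=O)=O)s1`) has not been measured yet. Its structure departs from that of compound 3 in one place ((((methoxymethyl)carbonyl)oxy)methyl in place of acetoxy on a saturated chain carbon, two bonds along the chain from a sulfonyl sulfur), on a saturated chain carbon, two bonds along the chain from a sulfonyl sulfur. Going by the values given here, no two measured compounds differ in only one place, which leaves the data without a direct guide to the size of such a step. The expectation therefore starts from compound 3 at 8.65 as a reference, since compound 4 keeps the rest of that structure unchanged. No step beyond the scatter is expected in this assay, and no firm direction can be given. The estimated move is a number 0.05 log units higher from compound 3 to compound 4 (within the scatter) and remains small. Expected for compound 4 is 8.7 with 8.35 to 9.05 as its estimated range.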

Compound 4, acid dissociation constant: 8.1
Compound 4: middle estimate off by 0.60 log units, on the high side; the measured number lies below the stated range.
By their numbers in this assay, from the lowest: compound 4; then compound 3; then compound 2; then compound 1.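

In this assay, going by these compounds alone, putting (((methoxymethyl)carbonyl)oxy)methyl in place of acetoxy on a saturated chain carbon, two bonds along the chain from a sulfonyl sulfur, gives a number 0.55 log units lower from compound 3 to compound 4 (beyond the scatter), the first step in this set that isolates a change in one place. It shows that the read-out responds to a change at this position, even though the entering group, with 7 heavy atoms against 4 and 3 hydrogen-bond acceptors against 2, brings no ring, no hydrogen-bond donor and no net charge, and keeps the 1 double bond outside aromatic rings that acetoxy also has. Nothing in the available data accounts for the origin of this step.

This single step cannot separate the contribution of the methoxymethyl part from that of the extended link in the entering group. As far as these compounds go, it also remains open whether a hydroxyl group, an amine or a carboxylic acid at this chain carbon would move the number in the same direction, and whether the step would carry over to a different core.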